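A few compounds are considered here, and "the series" means these few. Any claim that something is new, unique, unknown or untested is made for them only; others in the source may bear on it.

In a functional assay (aorta) with Oryctolagus cuniculus as the target (a lower number here means tighter binding, a higher number weaker binding), compound 1 `COC(=O)c1ccc(OCCCN2CCC(C(c3ccc(F)cc3)c3ccc(F)cc3)CC2)c(OC)c1` gives 1.26 nM and compound 2 `COc1ccccc1OCCCN1CCC(C(c2ccc(F)cc2)c2ccc(F)cc2)CC1` gives 2.51 nM and stands level with compound 1 within the scatter. Compound 3 `Fc1ccc(C(c2ccc(F)cc2)C2CCN(CCCOc3ccc4ccccc4c3)CC2)cc1` differs from compound 2 by naphthalen-2-yl in place of 2-methoxyphenyl on an oxygen on a saturated carbon with naphthalen-2-yl in place of 2-methoxyphenyl on an oxygen on a saturated carbon. Within the data shown here, the one measured step, hydrogen in place of methoxycarbonyl on an aromatic carbon, is a 2.0-fold higher number from compound 1 to compound 2 (0.30 log units; within the scatter) and does not cover this exchange, so no step beyond the scatter is expected in this assay for compound 3. The expected change is a 1.2-fold higher number from compound 2 to compound 3 (0.08 log units; within the scatter) in this estimate. Compound 3 is estimated at 3 nM (0.8 nM to 12 nM).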

Compound 3, dissociation constant: 7.94 nM
Compound 3: middle estimate off by 2.6-fold (0.42 log units), on the low side; the range from low to high includes it.
By their numbers in this assay, from the lowest: compounds 1 and 2 (each within the scatter of the next); then compound 3.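

In this assay, among these compounds, this is the first exchange to move the number beyond the scatter: naphthalen-2-yl in place of 2-methoxyphenyl on the oxygen gives a 3.2-fold higher number from compound 2 to compound 3 (0.50 log units; beyond the scatter), and in place of 2-methoxy-4-(methoxycarbonyl)phenyl it gives a 6.3-fold higher number from compound 1 to compound 3 (0.80 log units; beyond the scatter). Both steps are modest, so the position accepts the two-ring group with only a limited rise in the number. Nothing measured here explains the shift.

The exchange removes the methoxy group and adds a second ring together, so their separate contributions remain unresolved. An unsubstituted phenyl group or naphthalen-1-yl at this position would separate these readings.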